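Thromboxane receptor antagonists: aryl ether to aryl amine

This account rests on a few compounds, and the source may have more. Where it says the series, first, only, none or still open, it means among the compounds named here.

Three sulfonylureas share one core and differ only in the aryl group on the ether oxygen. In a functional assay on HEK293 cells for antagonist activity at thromboxane A2 receptor (Homo sapiens), read by fluorescence and calcium flux (on this read-out higher numbers stand for weaker inhibition and lower numbers for stronger inhibition), compound 1 `CCCCCNC(=O)NS(=O)(=O)c1cc(C#N)ccc1Oc1cccc(C)c1` gives 680 nM and compound 2 `CCCCCNC(=O)NS(=O)(=O)c1cc(C#N)ccc1Oc1ccc(C)cc1` gives 630 nM; the change of a 1.1-fold lower number from compound 1 to compound 2 (0.03 log units; within the scatter) is within the scatter. Compound 3 `CCCCCNC(=O)NS(=O)(=O)c1cc(C#N)ccc1Oc1ccc(F)cc1` gives 9530 nM and stands as the highest number of the three, with a 14-fold higher number from compound 1 to compound 3 (1.15 log units; beyond the scatter) and a 15-fold higher number from compound 2 to compound 3 (1.18 log units; beyond the scatter).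

Compound 4 `CCCCCNC(=O)NS(=O)(=O)c1cc(C#N)ccc1Nc1ccccc1C` is not yet measured. It differs from compound 3 by (2-methylphenyl)amino in place of 4-fluorophenoxy on an aromatic carbon. Two things change at once: the aryl group regains a methyl, and the linking atom changes from oxygen to nitrogen. The measured steps bear only on the first part: from compound 2 to compound 3 the methyl-to-fluoro exchange cost a 15-fold higher number from compound 2 to compound 3 (1.18 log units; beyond the scatter), so returning a methyl-bearing phenyl is expected to recover part of that. Nothing measured speaks to the oxygen-to-nitrogen exchange or to the 2-position of the methyl, so the recovery is expected to be partial and uncertain. The estimated step is a 6.4-fold lower number from compound 3 to compound 4 (0.80 log units; beyond the scatter). Compound 4 is therefore expected at 1500 nM, with a range from 400 nM to 6000 nM.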

Compound 4, half-maximal inhibitory concentration: 7850 nM
For compound 4 the middle estimate is 5.2-fold (0.72 log units) below the measured one; the whole stated range lies below it.
By their numbers in this assay, from the lowest: compounds 2 and 1 (each within the scatter of the next); then compounds 4 and 3 (each within the scatter of the next).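

Replacing the ether link and moving the methyl does not restore the lower numbers in this assay: (2-methylphenyl)amino cannot be told apart from 4-fluorophenoxy (a 1.2-fold lower number from compound 3 to compound 4 (0.08 log units; within the scatter)), yet it stays well off both methylphenoxy compounds (a 12-fold higher number from compound 2 to compound 4 (1.10 log units; beyond the scatter); a 12-fold higher number from compound 1 to compound 4 (1.06 log units; beyond the scatter)). A methyl on the aryl group is therefore not sufficient at this position, and the earlier indifference between 3-methylphenyl and 4-methylphenyl on oxygen does not carry over to this changed group. No evidence at hand accounts for this result.

Since the nitrogen link and the methyl position change together in compound 4, the large step cannot be assigned to either one. A 2-methylphenoxy or a (4-methylphenyl)amino group at this position would separate the two.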